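A few compounds are considered here, and "the series" means these few. Any claim that something is new, unique, unknown or untested is made for them only; others in the source may bear on it.

Compound 1 `COc1ccccc1C(=O)Nc1ccc(Sc2nc3ccccc3s2)c(Cl)c1` and compound 2 `O=C(Nc1ccc(Sc2nc3ccccc3s2)c(Cl)c1)c1ccccc1O` share one core and differ only at an oxygen on an aromatic ring. In an assay on isolated protein for inhibition of thiosulfate sulfurtransferase (Homo sapiens), with a stated time of 60 min, in the absence of a further agent (a higher number here means a weaker inhibitor, a lower number a stronger inhibitor), compound 1 reaches only the assay limit, > 100000 nM. Compound 2 in this assay likewise sits at the limit, > 100000 nM. The step that the two limits leave unreadable from compound 1 to compound 2 is unreadable because both values rest on (the limit of > 100000 nM in this assay, at which 2 of the 2 values shown sit). Compound 3 `COc1ccc(Br)cc1C(=O)Nc1ccc(Sc2nc3ccccc3s2)c(Cl)c1` carries 5-bromo-2-methoxyphenyl in place of 2-hydroxyphenyl on a carbonyl carbon. Among the measured compounds shown here, no measured step reads, so no size or direction beyond the scatter can be drawn for this assay. Compound 3 is expected at 150000 nM, within 30000 nM to 1000000 nM. The expected step that the limit leaves unreadable from compound 2 to compound 3 is accordingly taken as none beyond the scatter.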

Compound 3, half-maximal inhibitory concentration: > 100000 nM
Compound 3: no number, only a limit; the forecaster's own chance of this, stated with the estimate: 80%; the middle value does not contradict the limit.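

Among the compounds shown here, compound 3 gives only a limit in this assay, so no step from compound 1 or compound 2 to compound 3 can be read: the limit of > 100000 nM in this assay, at which 3 of the 3 values shown sit. The compounds shown leave open whether any change to the shared core gives a readable value in this assay.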